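Nitro to cyano on the hydroxyphenyl urea

The source may hold more compounds than are shown below. What is called first, only, known or untested is meant among the compounds shown, and "the series" means these compounds.

Two phenylurea compounds have been measured so far in an assay for inhibition of C-X-C chemokine receptor type 1 (Homo sapiens), read by radioligand binding; on this read-out higher numbers stand for weaker inhibition and lower numbers for stronger inhibition. Compound 1 `O=C(Nc1ccccc1)Nc1ccc([N+](=O)[O-])cc1O` gives 18200 nM and stands as the lower of the two numbers. Compound 2 `O=C(Nc1ccccc1)Nc1cc([N+](=O)[O-])ccc1O` gives 46200 nM in this assay, a gap to compound 1 that lies beyond the usual scatter. Going by the values given here, no step between these two measured compounds has been worked out, so the pair offers only its two values.

Compound 3 `N#Cc1ccc(NC(=O)Nc2ccccc2)c(O)c1` has not yet been measured. It differs from compound 1 by cyano in place of nitro on an aromatic carbon. With no measured step of this kind in the series, the expectation is for no change beyond the scatter, with at most a small step in either direction. Compound 3 is therefore expected to give 25000 nM in this assay, with a range from 8000 nM to 80000 nM, which would mean a step of a 1.4-fold higher number from compound 1 to compound 3 (0.14 log units; within the scatter).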

Compound 3, half-maximal inhibitory concentration: 21000 nM
The estimate for compound 3 lay 1.2-fold (0.08 log units) above the measured number; the range from low to high includes it.
By their numbers in this assay, from the lowest: compounds 1 and 3 (each within the scatter of the next); then compound 2.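

In this assay, cyano in place of nitro on an aromatic carbon, para to a large group and meta to a hydroxy group, gives a 1.2-fold higher number from compound 1 to compound 3 (0.06 log units; within the scatter). Going by these compounds alone, this is the first reading of a change at this position, and at this level of inhibition the read-out does not tell nitro, with its 3 heavy atoms, from cyano, with its 2, so nitro is not needed here to keep the value of compound 1. No measured property on hand bears on this result.

From the compounds shown here alone, it remains open whether an amine, a carboxylic acid or a methoxy group at this position would also stay within the scatter of compound 1. Going by these compounds, it is also open whether cyano in place of nitro on the core of compound 2 would give as small a step.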